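Furan-2-yl to 1,3-thiazol-2-yl on the ethenyl chain

The source may report more compounds than this note shows. Statements on the series, on what has been measured and on what is new or still open speak of the compounds shown alone.

Measured in a functional assay on A-431 cells (Homo sapiens) for cytotoxicity; a lower number here means that less compound is needed, a higher number that more compound is needed for the effect:
compound 1 `COC1=C(C)C(=O)/C(=C(O)/C=C/c2ccccc2OC)C(=O)C1(C)C` gives 6.6 ug/mL
compound 2 `COC1=C(C)C(=O)/C(=C(O)/C=C/c2cc(C)cc(C)c2)C(=O)C1(C)C` gives 4 ug/mL
compound 3 `COC1=C(C)C(=O)/C(=C(O)/C=C/c2ccco2)C(=O)C1(C)C` gives 14.7 ug/mL

Compound 3 stands highest of the three, beyond the scatter from both others. Within the data shown here, compound 4 `COC1=C(C)C(=O)/C(=C(O)/C=C/c2nccs2)C(=O)C1(C)C` differs from it by 1,3-thiazol-2-yl in place of furan-2-yl on a double-bonded chain carbon bound to a double-bonded chain carbon as the only change. Swaps at this place are the only evidence: a 2.2-fold higher number from compound 1 to compound 3 (0.35 log units; beyond the scatter) and a 3.7-fold higher number from compound 2 to compound 3 (0.57 log units; beyond the scatter) were modest, while a 1.7-fold lower number from compound 1 to compound 2 (0.22 log units; within the scatter) stayed within the scatter. Those two modest steps exchanged a substituted phenyl for furan-2-yl, whereas here a five-membered aromatic ring stays in place. No step beyond the scatter is therefore expected in this assay for this change. The estimated step is a 1.1-fold lower number from compound 3 to compound 4 (0.05 log units; within the scatter) and remains small. For compound 4 the estimated value is 13 ug/mL with an expected range from 6 ug/mL to 28 ug/mL in this assay.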

Compound 4, concentration for half-maximal effect: 6 ug/mL
For compound 4 the middle estimate is 2.2-fold (0.34 log units) above the measured one; the range from low to high includes it.
By their numbers in this assay, from the lowest: compounds 2, 4 and 1 (each within the scatter of the next); then compound 3.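

In this assay this place responds even when a five-membered aromatic ring stays in it (a 2.5-fold lower number from compound 3 to compound 4 (0.39 log units; beyond the scatter)), so swaps against a substituted phenyl are not the only ones that move the number. With 1,3-thiazol-2-yl, the five-membered ring no longer sets compound 4 apart from the substituted phenyl compounds (a 1.5-fold higher number from compound 2 to compound 4 (0.18 log units; within the scatter); a 1.1-fold lower number from compound 1 to compound 4 (0.04 log units; within the scatter)), which leaves compound 3 alone with the highest number of the four. No available data explain the difference between the two rings. Open, on these data alone, is whether an amine or a carboxylic acid on the 1,3-thiazol-2-yl ring keeps the number, and whether a longer chain in place of the ethenyl chain does.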